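The source may report more compounds than this note shows. Statements on the series, on what has been measured and on what is new or still open speak of the compounds shown alone.

Three compounds have been measured in a functional assay (Homo sapiens) for inhibition of Nucleic Acid, tested at 100 uM; a higher number here means more inhibition at the concentration tested (going by the name of the read-out), a lower number less inhibition:

Compound 1, `[N-]=[N+]=Nc1nccc2c1ncn2[C@H]1C[C@H](O)[C@@H](CO)O1`: 4%
Compound 2, `CN(C)c1nccc2c1ncn2[C@H]1C[C@H](O)[C@@H](CO)O1`: 0%
Compound 3, `CN(C)c1[nH]ccc2ncnc1-2`: 8%

All three readings are small, and every gap between them lies within the usual scatter of this kind of measurement, so none of them can be said to differ from another. Compound 2 and compound 1 share a core and differ in one place: azido in place of dimethylamino on an aromatic carbon. The step that this change made is a number 4 percentage points higher from compound 2 to compound 1 (within the scatter), which is to say that it made no difference that can be seen through the scatter.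

Compound 3 has a different core from compound 2; the difference between the two cores is not broken down here. Compound 4, `[N-]=[N+]=Nc1[nH]ccc2ncnc1-2`, has not yet been measured. It stands to compound 3 as compound 1 stands to compound 2: azido in place of dimethylamino on an aromatic carbon. The surroundings of the place are described in the same words in both pairs, so this is the same change, made on a second core.

Among the measured compounds shown here, the only guide to what it will do is the one earlier occurrence. Since that change gave a number 4 percentage points higher from compound 2 to compound 1 (within the scatter), the step in this assay from compound 3 to compound 4 is expected to be small as well, about a number 2 percentage points higher from compound 3 to compound 4 (within the scatter). On that basis compound 4 is estimated at 10%, with a likely range from 0% to 25%. This rests on a single earlier step, so it is a loose expectation.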

Compound 4, a percentage reported as inhibition, at one concentration (the size of the read-out at that concentration, not a potency): 20%
Estimate against measurement, compound 4: 10 percentage points below, and the stated range covers the measured number.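

In this assay, putting azido in place of dimethylamino on the core of compound 3 gave a number 12 percentage points higher from compound 3 to compound 4 (beyond the scatter). Set beside the earlier occurrence of the same change, this step does not stand apart from it: the same change on two cores in this assay, a number 4 percentage points higher (within the scatter) from compound 2 to compound 1 and a number 12 percentage points higher (beyond the scatter) from compound 3 to compound 4, 8 percentage points apart, within the scatter of two such steps. So there is no sign that the core alters what this change does, but that is not proof that the two cores respond alike, as only one of the two steps stands clear of the scatter and two pairs are too few to make a rule for the series.

The compounds shown leave open how other groups on this aromatic carbon, such as a primary amine, a methoxy group or a chlorine atom, would read in this assay on either core. They also leave open whether azido in place of dimethylamino would give a similar step on a third core, and whether the larger step on the core of compound 3 would hold up in repeated measurements.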